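A few compounds are considered here, and "the series" means these few. Any claim that something is new, unique, unknown or untested is made for them only; others in the source may bear on it.

Among the compounds with values here, compound 1 `CCOc1cc(C)c(Cl)c2c1C(=O)C=CC2=O` gives 40000 nM in a functional assay on MCF7 cells (Homo sapiens) for cytotoxicity, read by XTT assay, with a stated time of 24 h (on this read-out lower numbers stand for stronger inhibition and higher numbers for weaker inhibition), the highest of the three numbers so far. Compound 2 `Cc1cc(O)c2c(c1Cl)C(=O)C=CC2=O` gives 15700 nM and compound 3 `CC(=O)Oc1c(C)cc(Cl)c2c1C(=O)C=CC2=O` gives 18700 nM in this assay. Within the data shown here, the only single-point step available, a 2.5-fold lower number from compound 1 to compound 2 (0.41 log units; beyond the scatter), concerns the substituent on the ring oxygen and leaves the chloro untouched. Among the measured compounds shown here, compound 4 `CCOc1cc(C)cc2c1C(=O)C=CC2=O` differs from compound 1 as follows: hydrogen in place of chloro on an aromatic carbon No measured step bears on removal of the chloro, so no step beyond the scatter is expected in this assay from this change, in either direction, though the uncertainty is wide. Compound 4 is therefore estimated at 40000 nM, within a range of 15000 nM to 120000 nM. This estimate for compound 4 amounts to an expected no change at the digits printed from compound 1 to compound 4 (within the scatter).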

Compound 4, half-maximal inhibitory concentration: 23700 nM
Compound 4: middle estimate off by 1.7-fold (0.23 log units), on the high side, and the stated range covers the measured number.
By their numbers in this assay, from the lowest: compounds 2, 3, 4 and 1 (each within the scatter of the next, the first and the last beyond it).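

Hydrogen in place of chloro on the aromatic carbon para to the ethoxy group gives a 1.7-fold lower number from compound 1 to compound 4 (0.23 log units; within the scatter) in this assay, so this position keeps its read-out within the scatter without the chloro. On this single pair, the chloro is not required for the micromolar-range cytotoxicity of compound 1. No measurement available here accounts for this step.

On these data alone, whether removal of the chloro behaves the same way alongside the free hydroxyl of compound 2 or the acetyl-bearing oxygen of compound 3 remains open. Also open, as far as these compounds go, is what a bromo, a methoxy or an amine would give on this carbon.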